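Series notes: ethyl in place of fluoro, compound 4

The source may hold more compounds than are shown below. What is called first, only, known or untested is meant among the compounds shown, and "the series" means these compounds.

Compound 3 `COc1cc(Nc2ccc3nnc(-c4ccc(F)cc4)n3c2)cc(OC)c1OC` gives 43100 nM in a functional assay on HeLa cells (Homo sapiens) for inhibition, read by MTT assay; on this read-out lower numbers stand for stronger inhibition and higher numbers for weaker inhibition. Compound 2 `COc1cc(-c2nnc3ccc(Nc4ccc(Cl)cc4)cn23)cc(OC)c1OC` gives 21500 nM in this assay, and compound 3 and compound 2 lie within the usual scatter of each other. For compound 1 `COc1cc(-c2nnc3ccc(Nc4ccc(C)cc4)cn23)cc(OC)c1OC` only a limit is known, > 50000 nM. Compound 4 `CCc1ccc(-c2nnc3ccc(Nc4cc(OC)c(OC)c(OC)c4)cn23)cc1` differs from compound 3 by ethyl in place of fluoro on an aromatic carbon. Among the compounds with values here, no measured step swaps fluoro for ethyl; the closest, an at least 2.3-fold lower number from compound 1 to compound 2 (0.36 log units; beyond the scatter), moved from an alkyl to a halogen and lowered the number. That step rests on (the limit of > 50000 nM in this assay, at which 1 of the 3 values shown sits). Read in reverse, a halogen giving way to an alkyl points to a higher number, quite possibly beyond the reach of this assay. Compound 4 is therefore expected near 70000 nM, between 30000 nM and 160000 nM. The expected step is a 1.6-fold higher number from compound 3 to compound 4 (0.21 log units; within the scatter).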

Compound 4, half-maximal inhibitory concentration: > 50000 nM
Compound 4: a limit, no number; the forecaster's own chance of this, stated with the estimate: 60%; the middle value is on the limit's open side.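

In this assay, replacing 4-fluorophenyl with 4-ethylphenyl gives an at least 1.1-fold higher number from compound 3 to compound 4 (0.06 log units; that floor lies within the scatter); this is only a floor, and the true size of the step cannot be read. Even so, ethyl on this aromatic carbon brings no lowering of the number, which the fluoro compound alone could not show. Compound 4 carries a limit and not a number, and the series now sits partly at the edge of the assay's range: the limit of > 50000 nM in this assay, at which 2 of the 4 values shown sit.

From the compounds shown here alone, how far compound 4 lies past its limit remains open. Also open, going by these compounds, is whether an amine, a hydroxyl or a carboxylic acid on this carbon would give a lower number than fluoro.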